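Chain-terminus changes on the shared core

The source may report more compounds than this note shows. Statements on the series, on what has been measured and on what is new or still open speak of the compounds shown alone.

Compound 1 `O=C(O)CCCCOc1cc(-c2ccccc2)c2ccccc2n1` gives 0% in an assay on membranes from spleen (Cavia porcellus) for binding affinity to leukotriene B4 receptor 1 (Homo sapiens), tested at 10 uM; on this read-out higher numbers stand for more inhibition at the one concentration tested (going by the name of the read-out) and lower numbers for less inhibition; compound 2 `O=C(O)CCCC/C=C/c1cc(-c2ccccc2)c2ccccc2n1` gives 27%, and compound 3 `O=C(CCCCCOc1cc(-c2ccccc2)c2ccccc2n1)N1CCCC1` gives 12%. Compound 3 therefore holds the second highest of the three numbers, with compound 1 nearer and compound 2 further away. Compound 4 `OCCCCCCOc1cc(-c2ccccc2)c2ccccc2n1` carries hydroxymethyl in place of (pyrrolidin-1-yl)carbonyl on a saturated chain carbon, five bonds along the chain from an oxygen on an aromatic ring. Going by the values given here, only one measured step concerns the end of the chain, a number 12 percentage points higher from compound 1 to compound 3 (beyond the scatter), and it was modest. Among the compounds with values here, no measured pair removes the (pyrrolidin-1-yl)carbonyl while adding a hydroxymethyl, so the direction is open. Because compound 1 gives 0% without that group, a small move downward is expected for compound 4, a number 6 percentage points lower from compound 3 to compound 4 (within the scatter), within the scatter or only just beyond it. Compound 4 is thus estimated at 6%, with a range from 0% to 20%.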

Compound 4, a percentage reported as inhibition, at one concentration (the size of the read-out at that concentration, not a potency): 14%
Estimate against measurement, compound 4: 8 percentage points below; measured number inside the range.
By their numbers in this assay, from the lowest: compound 1; then compounds 3 and 4 (each within the scatter of the next); then compound 2.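

In this assay, a number 2 percentage points higher from compound 3 to compound 4 (within the scatter), so at this chain end hydroxymethyl and (pyrrolidin-1-yl)carbonyl are not told apart, even though the five-membered ring leaves with the change. Both departures from the carboxy compound rise, a number 14 percentage points higher from compound 1 to compound 4 (beyond the scatter), alongside a number 12 percentage points higher from compound 1 to compound 3 (beyond the scatter), and in each the terminal group and the chain length change together. No supporting data explain these numbers.

A carboxylic acid on the longer chain of compound 4 would separate those two changes. On these data alone, an amine at the chain end remains untested against hydroxymethyl.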